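Cytotoxicity notes on a pair of amide regioisomers

The compounds below may be only part of what the source reports. "The series", "measured", "known", "first", "only" and "open" are said of these compounds alone.

Compound 1 `Cc1ccn2nc(C)c(C(=O)NCc3ccc(N4CCC(c5ccc(OC(F)(F)F)cc5)CC4)cc3)c2c1` has been examined in an ADME assay on Vero cells (Chlorocebus sabaeus) for cytotoxicity, read by CCK-8 assay, with a stated time of 72 h; a higher number here means a weaker inhibitor, a lower number a stronger inhibitor. In this assay compound 1 gives only a limit, > 100000 nM, and no number. Compound 2 `Cc1nn2cccc(C)c2c1C(=O)NCc1ccc(N2CCC(c3ccc(OC(F)(F)F)cc3)CC2)cc1` has no result in this assay, so its standing rests on nothing measured; its entry there reads "not determined" (no result reported). Compound 3 `Cc1ccc2c(C(=O)NCc3ccc(N4CCC(c5ccc(OC(F)(F)F)cc5)CC4)cc3)c(C)nn2c1` has not been measured. The change from compound 2 to compound 3 is a group of 11 heavy atoms (9 carbon, 2 nitrogen; one five-membered aromatic ring with 2 hetero atoms, one six-membered aromatic ring with 1 hetero atom) in place of a group of 11 heavy atoms (9 carbon, 2 nitrogen; one five-membered aromatic ring with 2 hetero atoms, one six-membered aromatic ring with 1 hetero atom), on a carbonyl carbon. Among the compounds with values here, no step between measured compounds is available to size this change; the only measured value in this assay is the limit reached by compound 1, (the limit of > 100000 nM in this assay, at which 1 of the 2 values shown sits). For compound 3 no step beyond the scatter is expected in this assay, in either direction. Compound 3 is estimated at 100000 nM, with a range from 30000 nM to 300000 nM, most likely again reported only as a limit.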

Compound 3, half-maximal inhibitory concentration: > 100000 nM
Compound 3: no number, only a limit; the forecaster's own chance of this, stated with the estimate: 80%; the middle value lies on the limit itself.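

No step can be read from compound 1 to compound 3 in this assay, since each gives only a limit and no number: the limit of > 100000 nM in this assay, at which 2 of the 3 values shown sit.

The compounds shown leave open whether exchanging the group on the carbonyl carbon changes cytotoxicity at all, and at what concentration any would appear.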